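Halogen swap on the sulfonamide aryl of a piperazine series

The source may report more compounds than this note shows. Statements on the series, on what has been measured and on what is new or still open speak of the compounds shown alone.

Compound 1 `COc1ccc(S(=O)(=O)Nc2ccc(C)cc2Br)cc1N1CCNCC1` gives 7.94 nM in an assay on isolated protein for binding affinity to 5-hydroxytryptamine receptor 6 (Homo sapiens); on this read-out lower numbers stand for stronger inhibition and higher numbers for weaker inhibition.
Compound 2 `COc1cc(Cl)c(C)cc1NS(=O)(=O)c1ccc(OC)c(N2CCNCC2)c1` gives 2 nM in this assay.

Of the two measured numbers in this assay, compound 1 has the higher one; compound 2 sits below it by a gap that is beyond the usual scatter. Compound 3 `COc1ccc(S(=O)(=O)Nc2cc(Cl)cc(Cl)c2Br)cc1N1CCNCC1` is not yet measured. It differs from compound 1 by 2-bromo-3,5-dichlorophenyl in place of 2-bromo-4-methylphenyl on a sulfonamide nitrogen. Within the data shown here, no measured pair in this set isolates this change, so the expected size of the step rests on compound 1 alone. Because compound 1 gives 7.94 nM, the estimate for compound 3 is anchored there, and the step from compound 1 to compound 3 is expected to be small, a 1.3-fold lower number from compound 1 to compound 3 (0.12 log units; within the scatter), with no direction that can be called beyond the scatter. Compound 3 is therefore estimated at 6 nM, with a plausible range from 1.5 nM to 25 nM.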

Compound 3, inhibition constant: 3.16 nM
Estimate against measurement, compound 3: 1.9-fold (0.28 log units) above; the measured number falls inside the stated range.
By their numbers in this assay, from the lowest: compounds 2 and 3 (each within the scatter of the next); then compound 1.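

In this assay, the group on a sulfonamide nitrogen now has its first measured step: 2-bromo-3,5-dichlorophenyl in place of 2-bromo-4-methylphenyl gives a 2.5-fold lower number from compound 1 to compound 3 (0.40 log units; beyond the scatter). This shows that the number at this place responds to the substituents on the aryl ring even with the bromine kept, and that the methyl can be given up without a loss in this read-out. The step covers the loss of the methyl and the arrival of the two chlorines together, and this single pair cannot divide it between them, nor does any measurement bear on why the number moves.

As far as these compounds go, whether one chlorine alone would give the same step, and whether the bromine matters at all, remains open. Also open, from the compounds shown here alone, is how a trifluoromethyl or nitrile group on this aryl ring would read in this assay.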